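The source may report more compounds than this note shows. Statements on the series, on what has been measured and on what is new or still open speak of the compounds shown alone.

Of the compounds shown here, three sharing one core have been measured in a physicochemical assay for lipophilicity, at pH 7.4; a higher number here means a more lipophilic compound, a lower number a more polar compound. Compound 1 `CNC(=O)c1cc(C(=O)NC2CC2)cn(CC2CCOCC2)c1=O` gives 1.5, compound 2 `CNC(=O)c1cc(C(=O)NC)c(=O)n(Cc2ccccc2)c1` gives 2.4, and compound 3 `CNC(=O)c1ccc(=O)n(Cc2ccccc2)c1` gives 1.6. Compound 1 thus sits at the low end of the three: its number lies within the scatter of compound 3 and well below compound 2. Among the compounds with values here, the only single-point step among them, a number 0.80 log units lower from compound 2 to compound 3 (beyond the scatter), concerns an amide group, not the group on the ring nitrogen, so it does not bear directly on what follows.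

Compound 4 `CNC(=O)c1cc(C(=O)NC2CC2)cn(Cc2ccccc2F)c1=O` differs from compound 1 by 2-fluorophenyl in place of oxan-4-yl on a saturated chain carbon bound to an aromatic nitrogen. Within the data shown here, no measured pair shows this exact change. The expectation rests on compound 2, which, with 2.4, also carries a six-membered aromatic ring of carbon only on the saturated chain carbon bound to the aromatic nitrogen and stands well above compound 1, although the two differ in a second place as well. A rise beyond the scatter is therefore expected, a number 1.40 log units higher from compound 1 to compound 4 (beyond the scatter). Compound 4 is estimated at 2.9, between 2.4 and 3.4.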

Compound 4, distribution coefficient: 3
Estimate against measurement, compound 4: 0.10 log units below; the range from low to high includes it.
By their numbers in this assay, from the lowest: compounds 1 and 3 (each within the scatter of the next); then compound 2; then compound 4.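

Before this result, no measured pair isolated the group on a saturated chain carbon bound to an aromatic nitrogen. Now a single change at that place, 2-fluorophenyl in place of oxan-4-yl, gives in this assay a number 1.50 log units higher from compound 1 to compound 4 (beyond the scatter), so with the rest of the molecule held fixed, this group alone can move the number by a large step. Nothing available here accounts for the size of that step.

The change swaps a non-aromatic ring holding one oxygen for an aromatic carbon ring carrying one fluorine, and the compounds shown leave open how much of the step belongs to each difference. Unsubstituted phenyl at this place would isolate the fluorine, while cyclohexyl would isolate the ring oxygen.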